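The compounds below may be only part of what the source reports. "The series", "measured", "known", "first", "only" and "open" are said of these compounds alone.

Measured so far:
Compound 1, `Cc1cc(Nc2cc(-c3ccccc3)[nH]n2)n2nc(SCc3cccc(Br)c3)nc2n1`: in an ADME assay on GES1 cells (Homo sapiens) for inhibition, read by MTT assay, with a stated time of 72 h (a higher number here means a weaker inhibitor, a lower number a stronger inhibitor), compound 1 gives > 50000 nM, which is a limit of the assay rather than a number.
Compound 2, `CCCCCc1c(C)nc2nc(SCc3ccc(Cl)cc3)nn2c1Nc1cc(-c2ccccc2)[nH]n1`: in this assay compound 2 gives > 50000 nM, again a limit of the assay.
Compound 3, `Cc1cc(Nc2cc(-c3ccc(F)cc3)[nH]n2)n2nc(SCc3ccc(Br)cc3)nc2n1`: in this assay compound 3 gives 34200 nM.

Compound 1 therefore stands at the upper edge of what this assay reports, and its value cannot be ordered against that of compound 2 or compound 3; the set is marked by the limit of > 50000 nM in this assay, at which 2 of the 3 values shown sit, so all three compounds read as weak inhibitors here. For the measured compounds named here, no pair among them differs in a single place, so no measured step can be drawn.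

Compound 4, `C#CCSc1nc2nc(C)cc(Nc3cc(-c4ccccc4)[nH]n3)n2n1`, has not yet been measured in this assay. Its change from compound 1 is ethynyl in place of 3-bromophenyl on a saturated chain carbon bound to a sulfur. With every measured value sitting at or near the limit, no step beyond the usual scatter is expected: the step expected from compound 1 to compound 4 is a number no higher from compound 1 to compound 4 (the limit leaves the size open). Compound 4 is estimated at 50000 nM, between 20000 nM and 120000 nM, most likely reported as a limit once more.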

Compound 4, half-maximal inhibitory concentration: 45700 nM
Compound 4: the middle estimate sits 1.1-fold (0.04 log units) above what was measured; the range from low to high includes it.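

At this place, on a saturated chain carbon bound to a sulfur, the change from 3-bromobenzyl to propargyl gives an at least 1.0-fold lower number from compound 1 to compound 4 (0.03 log units; that floor lies within the scatter) in this assay. The aromatic ring of the 3-bromobenzyl group is therefore not needed for a numerical reading, as compound 4 gives 45700 nM with the small propargyl group in its place, and it still reads as a weak inhibitor. Compound 1 remains a limit of the assay, and the true size of the step stays unknown: the limit of > 50000 nM in this assay, at which 2 of the 4 values shown sit.

From the compounds shown here alone, what an amine or a carboxylic acid at the end of this chain would read in this assay remains open, as does whether any group at this place moves the number beyond the scatter. The compounds shown also leave open how the same change would read on compound 3, which has a measured value rather than a limit.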